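The source may hold more compounds than are shown below. What is called first, only, known or untested is meant among the compounds shown, and "the series" means these compounds.

Measured compounds so far:
compound 1, `CCN(CC)Cc1ccc(C)c(Nc2nc3ccccc3n2Cc2ccc(C#N)cc2)c1O`; compound 2, `CCN(CC)Cc1cc(F)cc(Nc2nc3ccccc3n2Cc2ccc(C(F)(F)F)cc2)c1O`; compound 3, `CC(C)(C)NCc1cc(Cl)cc(Nc2nc3cc(F)c(F)cc3n2Cc2ccc(C(F)(F)F)cc2)c1O`.

In an ADME assay on CHO cells (Cricetulus griseus) for inhibition, read by MTT assay (on this read-out higher numbers stand for weaker inhibition and lower numbers for stronger inhibition), compound 1 gives only a limit, > 50000 nM. In this assay compound 2 likewise gives only a limit, > 50000 nM. In this assay compound 3 also gives only a limit, > 50000 nM. Compound 2 therefore stands nowhere that can be ranked: its value is a limit, and the two further values shown are limits as well, since (the limit of > 50000 nM in this assay, at which 3 of the 3 values shown sit).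

The unmeasured compound 4, `CCN(CC)Cc1cc(C)cc(Nc2nc3ccccc3n2Cc2ccc(C(F)(F)F)cc2)c1O`, differs from compound 2 in one place: methyl in place of fluoro on an aromatic carbon. Among the measured compounds shown here, with the three measured values all sitting at the same limit, no step between measured compounds is available, and in this assay the step from compound 2 to compound 4 is expected to be none beyond the usual scatter, most likely leaving compound 4 at the limit too. Compound 4 is estimated at 50000 nM, within 20000 nM to 100000 nM. This estimate means the step of a number no higher from compound 2 to compound 4 (the limit leaves the size open) is expected to be flat.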

Compound 4, half-maximal inhibitory concentration: 29300 nM
Beside the measured number, compound 4's estimate is 1.7-fold (0.23 log units) above it; the range from low to high includes it.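

In this assay, among the compounds shown here, methyl on this aromatic carbon, para to the hydroxy group, gives the first value that can be read as a number, whereas fluoro at the same place in compound 2 gives only a limit. The change in this one place gives an at least 1.7-fold lower number from compound 2 to compound 4 (0.23 log units; that floor lies within the scatter), so it shows a lower number but cannot establish a real change, since compound 2 has no exact value to measure from. Compound 4 alone stands off the ceiling that holds the other compounds: the limit of > 50000 nM in this assay, at which 3 of the 4 values shown sit.

From the compounds shown here alone, how far compound 2 truly lies from compound 4 remains open, so the size of the step is unknown. Also open, going by these compounds, is whether a methoxy group or an amine at this position would give a number lower than methyl does.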